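Biaryl terminus swap in the cyclopropane-amide series

The source may report more compounds than this note shows. Statements on the series, on what has been measured and on what is new or still open speak of the compounds shown alone.

Compound 1, `CC[C@H](C)[C@H](N)CN(C(=O)[C@@H]1C[C@H]1c1ccc(Cl)cc1)c1ccc(-c2ccccc2)cc1`, in a functional assay for agonist activity at G protein-coupled receptor 88 (Homo sapiens), read by HTRF and cAMP accumulation (on this read-out lower numbers stand for an effect already at smaller amounts and higher numbers for an effect only at larger amounts of compound), gives 4300 nM.
Compound 2, `CC[C@H](C)[C@H](N)CN(C(=O)[C@@H]1C[C@H]1c1ccccn1)c1ccc(-c2ccccc2)cc1`, gives 130 nM.
Compound 3, `CC(C)C[C@H](N)CN(C(=O)[C@@H]1C[C@H]1c1ccccc1)c1ccc(-c2cccs2)cc1`, gives 1500 nM.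

Compound 3 stands second highest of the three numbers: its value lies beyond the scatter from compound 1 on the high side and from compound 2 on the low side, so it sits between them. Among the measured compounds shown here, the only step measured within one change, a 33-fold lower number from compound 1 to compound 2 (1.52 log units; beyond the scatter), is large, but it concerns the aryl on the saturated ring of the cyclopropane, not the aromatic carbon that changes here.

Compound 4, `CC(C)C[C@H](N)CN(C(=O)[C@@H]1C[C@H]1c1ccccc1)c1ccc(-c2ccccc2F)cc1`, is compound 3 with 2-fluorophenyl in place of thiophen-2-yl on an aromatic carbon. For the measured compounds named here, no measured step touches this position, so nothing in the data supports a directed step in this assay; the expectation is a change that stays within the scatter, in either direction.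

Compound 4 is therefore expected near 1200 nM, within 400 nM to 4000 nM. This estimate means a 1.3-fold lower number from compound 3 to compound 4 (0.10 log units; within the scatter), expected to remain inside the usual scatter.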

Compound 4, half-maximal effective concentration: 1600 nM
Compound 4: middle estimate off by 1.3-fold (0.12 log units), on the low side; the measured number falls inside the stated range.
By their numbers in this assay, from the lowest: compound 2; then compounds 3 and 4 (each within the scatter of the next); then compound 1.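

In this assay, among the compounds shown here, the exchange of thiophen-2-yl for 2-fluorophenyl, a 1.1-fold higher number from compound 3 to compound 4 (0.03 log units; within the scatter), is the first step read at this aromatic carbon, para to a large group. Sulfur leaves and fluorine enters, a five-membered aromatic ring gives way to a six-membered aromatic ring of carbon only, and the counted hydrogen-bond acceptor is lost, yet the number stays within the scatter, so this position accepts both groups with no readable difference here. No measured evidence bears on why the two groups read alike.

The compounds shown leave open whether a group of another kind at this place, such as an amine or a carboxylic acid, would read the same way. Also open, on these data alone, is whether the large step seen with pyridin-2-yl, a 33-fold lower number from compound 1 to compound 2 (1.52 log units; beyond the scatter), carries over to compounds bearing thiophen-2-yl or 2-fluorophenyl.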